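From 2-hydroxyphenyl to 3-hydroxyphenyl on a shared core

The source may hold more compounds than are shown below. What is called first, only, known or untested is meant among the compounds shown, and "the series" means these compounds.

Of the compounds shown here, three with one shared core have been tested in a toxicity assay on THP-1 cells (Homo sapiens) for inhibition; a higher number here means that more compound is tolerated, a lower number that less compound is tolerated. Compound 1 `COc1ccc(-c2cnc(NC(=O)c3ccccn3)n2C)cc1` carries pyridin-2-yl on a carbonyl carbon. In this assay compound 1 gives > 100000 nM, which is a limit of the assay rather than a measured number. Compound 2 `COc1ccc(-c2cnc(NC(=O)c3ccc(Cl)cc3)n2C)cc1` carries 4-chlorophenyl on that carbonyl carbon. In this assay compound 2 gives > 100000 nM, again a limit. Compound 3 `COc1ccc(-c2cnc(NC(=O)c3ccccc3O)n2C)cc1` carries 2-hydroxyphenyl on the carbonyl carbon. In this assay compound 3 gives > 100000 nM, also a limit. The steps a step that the two limits leave unreadable from compound 1 to compound 2, a step that the two limits leave unreadable from compound 1 to compound 3 and a step that the two limits leave unreadable from compound 2 to compound 3 cannot be read because of the limit of > 100000 nM in this assay, at which 3 of the 3 values shown sit. Compound 4 `COc1ccc(-c2cnc(NC(=O)c3cccc(O)c3)n2C)cc1` is not yet measured; it differs from compound 3 by 3-hydroxyphenyl in place of 2-hydroxyphenyl on a carbonyl carbon. Going by the values given here, the measured steps bear on this change only in showing that exchanging the group on the carbonyl carbon has so far brought no compound into the readable range. Compound 4 is therefore expected to sit at the limit again, with the step that the limit leaves unreadable from compound 3 to compound 4 expected to be small. The estimate for compound 4 in this assay is 150000 nM, ranging from 80000 nM to 300000 nM.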

Compound 4, half-maximal cytotoxic concentration: > 100000 nM
Compound 4 ended at the assay's limit (the forecaster's own chance of this, stated with the estimate: 85%); the middle value is on the limit's open side.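

Going by these compounds alone, no step among compound 1, compound 2, compound 3 and compound 4 can be read, because each value is a limit of the assay: the limit of > 100000 nM in this assay, at which 4 of the 4 values shown sit. The compounds shown leave open whether exchanging the group on the carbonyl carbon changes how much compound is tolerated.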